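The source may hold more compounds than are shown below. What is called first, only, known or untested is meant among the compounds shown, and "the series" means these compounds.

Measured compounds in a functional assay on MCF7 cells (Homo sapiens), tested at 7.5 uM; a lower number here means a stronger effect, a higher number a weaker effect of the compound at the concentration tested:
compound 1 `Cc1c(C)c2c(c(C)c1OC(=O)CCC(=O)O)CCC(C)(COc1ccc(/C=C3\SC(=O)NC3=O)cc1)O2`: 76%
compound 2 `Cc1c(C)c2c(c(C)c1OC/C=C/c1ccccc1)CCC(C)(COc1ccc(/C=C3\SC(=O)NC3=O)cc1)O2`: 43%
compound 3 `CCOc1cc(/C=C2\SC(=O)NC2=O)ccc1OCC1(C)CCc2c(C)c(OCC=C(C)C)c(C)c(C)c2O1`: 54%

Compound 3 stands second highest of the three; compound 2 sits a number lower and compound 1 a number higher, both beyond the scatter. Within the data shown here, the only measured step, a number 33 percentage points lower from compound 1 to compound 2 (beyond the scatter), concerns a 3-phenylprop-2-en-1-yl in place of (2-carboxyethyl)carbonyl on an oxygen on an aromatic ring, a different group at a different place, so it does not bear on the present change. Compound 4 `CC(C)=CCOc1c(C)c(C)c2c(c1C)CCC(C)(COc1ccc(/C=C3\SC(=O)NC3=O)cc1)O2` differs from compound 3 by hydrogen in place of ethoxy on an aromatic carbon. Among the measured compounds shown here, no measured pair covers a change of this kind, so no step beyond the scatter in this assay is expected, and the estimate rests on compound 3 with 54%. The expected step is no change at the digits printed from compound 3 to compound 4 (within the scatter). For compound 4 the estimated value is 54%, within 34% to 74%.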

Compound 4, a percentage reported as activity, at one concentration (the size of the read-out at that concentration, not a potency): 5%
Estimate against measurement, compound 4: 49 percentage points above; the measured number lies below the stated range.
By their numbers in this assay, from the lowest: compound 4; then compound 2; then compound 3; then compound 1.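

In this assay, the ethoxy on this aromatic carbon, ortho to a large group, matters: a number 49 percentage points lower from compound 3 to compound 4 (beyond the scatter) when hydrogen replaces it. With hydrogen at that carbon, the 3-methylbut-2-en-1-yl on the oxygen also gives a number 71 percentage points lower from compound 1 to compound 4 (beyond the scatter) and, against the 3-phenylprop-2-en-1-yl, a number 38 percentage points lower from compound 2 to compound 4 (beyond the scatter) in the same read-out. Nothing available here accounts for the size of these steps. From the compounds shown here alone, whether methoxy or fluorine at this carbon behaves like ethoxy or like hydrogen remains open. So does whether hydrogen here gives the same step with a carboxylic acid ester or 3-phenylprop-2-en-1-yl on the oxygen.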